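The source may hold more compounds than are shown below. What is called first, only, known or untested is meant among the compounds shown, and "the series" means these compounds.

Compound 1 (`O=C(N[C@H]1CN(S(=O)(=O)c2ccccc2)C[C@@H]1C(=O)N[C@H]1CCCNC1)c1cc(-c2ccccc2Cl)on1`) gives < 3 mL.min-1.g-1 in an ADME assay on microsomes from liver (Homo sapiens) for metabolic stability (on this read-out higher numbers stand for fast clearance and lower numbers for slow clearance), and this is a limit of the assay, not a number. Compound 2 (`O=C(N[C@H]1CN(S(=O)(=O)c2ccccc2)C[C@@H]1C(=O)NC[C@@H]1CCCN1)c1cc(-c2ccccc2Cl)on1`), with (pyrrolidin-2-yl)methyl in place of piperidin-3-yl on an amide-type nitrogen, gives a measured 9.7 mL.min-1.g-1. That change is an at least 3.2-fold higher number from compound 1 to compound 2 (0.50 log units; beyond the scatter).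

Compound 3 (`CN(C(=O)c1cc(-c2ccccc2Cl)on1)[C@H]1CN(S(=O)(=O)c2ccccc2)C[C@@H]1C(=O)N[C@H]1CCCNC1`) keeps the piperidin-3-yl of compound 1 and instead carries methyl in place of hydrogen on an amide-type nitrogen, whose other neighbours are a carbonyl carbon and a saturated ring carbon: methyl in place of hydrogen on an amide-type nitrogen. Among the compounds with values here, no measured step covers this change. Within the data shown here, the single step available lies at a different amide-type nitrogen and bears on it only loosely, as a sign that one small edit can lift the series off the limit.

A small upward move is expected in this assay, estimated as an at least 1.3-fold higher number from compound 1 to compound 3 (0.12 log units; that floor lies within the scatter). For compound 3 the expected value is 4 mL.min-1.g-1, with an estimated range of 2 mL.min-1.g-1 to 10 mL.min-1.g-1.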

Compound 3, intrinsic clearance in microsomes: 13 mL.min-1.g-1
For compound 3 the middle estimate is 3.3-fold (0.51 log units) below the measured one, and the stated range ends below it.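

In this assay, methyl in place of hydrogen on the amide-type nitrogen whose other neighbours are a carbonyl carbon and a saturated ring carbon gives an at least 4.3-fold higher number from compound 1 to compound 3 (0.63 log units; beyond the scatter), so this nitrogen also responds to a single small edit. Together with compound 2, two separate single edits to compound 1 now lift the read-out off the limit, and the edit in compound 3 adds only one carbon. The step is a floor rather than a full size, because compound 1 sits at a limit: the limit of < 3 mL.min-1.g-1 in this assay, at which 1 of the 3 values shown sits.

Going by these compounds, whether ethyl or a longer chain on this nitrogen would move the read-out further remains open. Also open, on these data alone, is whether the methyl step would hold on compound 2, with its (pyrrolidin-2-yl)methyl in place of piperidin-3-yl.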